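This account rests on a few compounds, and the source may have more. Where it says the series, first, only, none or still open, it means among the compounds named here.

Compound 1 `O=c1[nH]nc2n(c1=O)CCN2c1ccccc1` gives 7% in an ADME assay on Vero cells (Chlorocebus sabaeus) for cytotoxicity, with a stated time of 72 h, tested at 10 ug/mL; on this read-out lower numbers stand for a weaker effect and higher numbers for a stronger effect at the one concentration tested. Compound 3 `N/N=C1\NCCN1c1ccccc1` gives 0% in this assay, and compound 2 `N/N=C1\NCCN1c1ccccc1Cl` gives 0% in the same assay. The difference between the core of compound 1 and the core of compound 3 is not broken down here; the two values stand within the scatter of one another. From compound 3 to compound 2 the change is chloro in place of hydrogen on an aromatic carbon, and in this assay it gave no change at the digits printed from compound 3 to compound 2 (within the scatter).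

Compound 4 `O=c1[nH]nc2n(c1=O)CCN2c1cccc(Cl)c1` has not yet been measured in this assay. From compound 1 to compound 4 the change is chloro in place of hydrogen on an aromatic carbon. Going by the values given here, this is the same kind of change as the one between compound 3 and compound 2, not the same: there the chloro sits ortho to a group of 7 heavy atoms, here it sits meta to a large group. Compound 4 is expected to show a step of a number 1 percentage points higher from compound 1 to compound 4 (within the scatter), which rests on the earlier step of no change at the digits printed from compound 3 to compound 2 (within the scatter) staying within the scatter. Among the compounds with values here, with only that one pair to lean on, compound 4 is expected to give about 8%, with a likely range from 0% to 20%.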

Compound 4, a percentage reported as inhibition, at one concentration (the size of the read-out at that concentration, not a potency): 11%
Estimate against measurement, compound 4: 3 percentage points below; measured number inside the range.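

In this assay, chloro in place of hydrogen on an aromatic carbon gives a step of a number 4 percentage points higher from compound 1 to compound 4 (within the scatter). Set beside the earlier step on the other core, the change shows no difference between the two cores that can be told from scatter: the same change on two cores in this assay, no change at the digits printed (within the scatter) from compound 3 to compound 2 and a number 4 percentage points higher (within the scatter) from compound 1 to compound 4, 4 percentage points apart, within the scatter of two such steps

This agreement is weak support for carrying the change from one core to the other, as it rests on a single pair of small steps, and the chloro does not stand in the same place in the two pairs. It does not show that the change would carry over at another place on the ring, or on a further core, or that chloro has any real effect on this read-out in either core.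

Still open, from the compounds shown here alone, is whether a different group on the aromatic ring, such as a methoxy group, an amine or a carboxylic acid, would give a step beyond the scatter on either core. Also open, going by these compounds, is what a longer chain in place of the aromatic ring would do to the read-out.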